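This account rests on a few compounds, and the source may have more. Where it says the series, first, only, none or still open, it means among the compounds named here.

Measured so far in a functional assay on CCRF-CEM cells (Homo sapiens) for cytotoxicity, read by XTT assay, with a stated time of 3 days; a higher number here means a weaker inhibitor, a lower number a stronger inhibitor:
compound 1 `OC[C@H]1O[C@@H](n2cc(F)c3c(-c4ccco4)ncnc32)[C@H](O)[C@@H]1O`: 1400 nM
compound 2 `OC[C@H]1O[C@@H](n2cc(F)c3c(-c4ccsc4)ncnc32)[C@H](O)[C@@H]1O`: 560 nM

Compound 1 holds the higher of the two numbers, so it is the weaker inhibitor of the pair in this assay. The next step leads to compound 3 `OC[C@H]1O[C@@H](n2cc(F)c3c(-c4cc[nH]c4)ncnc32)[C@H](O)[C@@H]1O`, not yet measured. The change is 1H-pyrrol-3-yl in place of furan-2-yl on an aromatic carbon, with 1H-pyrrol-3-yl in place of furan-2-yl on an aromatic carbon. Among the compounds with values here, the only measured step that bears on this is a 2.5-fold lower number from compound 1 to compound 2 (0.40 log units; beyond the scatter), with thiophen-3-yl in place of furan-2-yl on that same carbon. That step is modest and beyond the scatter. Within the data shown here, no 1H-pyrrol-3-yl compound has a measured value yet, so this is a single, indirect guide. A modest step towards a lower number is therefore expected in this assay. The expected step is a 2.3-fold lower number from compound 1 to compound 3 (0.37 log units; beyond the scatter). For compound 3 the estimated value is 600 nM, with an expected range of 180 nM to 2000 nM.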

Compound 3, half-maximal inhibitory concentration: 930 nM
Compound 3: the middle estimate sits 1.6-fold (0.19 log units) below what was measured, and the stated range covers the measured number.
By their numbers in this assay, from the lowest: compounds 2, 3 and 1 (each within the scatter of the next, the first and the last beyond it).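

In this assay, 1H-pyrrol-3-yl on this aromatic carbon gives a 1.5-fold lower number from compound 1 to compound 3 (0.18 log units; within the scatter), and set against thiophen-3-yl it gives a 1.7-fold higher number from compound 2 to compound 3 (0.22 log units; within the scatter), so compound 3 cannot be separated from either of the other two. The position therefore takes a ring carrying a hydrogen-bond donor in place of one carrying a hydrogen-bond acceptor with no step beyond the scatter, and among the three five-membered aromatic rings only compound 1 and compound 2 stand apart. No measured property is at hand to explain these numbers. Still open, as far as these compounds go, is how a phenyl ring, an amine or a short alkyl chain on this carbon would compare with the five-membered rings. From the compounds shown here alone, with a single cell line, it also remains open whether these small differences carry over to other cells.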